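Sulfonyl aryl exchange in an acylsulfonamide tracheal antagonist series

The source may report more compounds than this note shows. Statements on the series, on what has been measured and on what is new or still open speak of the compounds shown alone.

Measured so far:
compound 1, `CCCCC(CC)C(=O)Nc1ccc2ccn(Cc3ccc(C(=O)NS(=O)(=O)c4ccc(Cl)cc4)cc3OC)c2c1`, gives 7.8 in a functional assay (trachea) for antagonist activity, with Cavia porcellus as the target; a lower number here means a less potent compound, a higher number a more potent compound, by a factor of ten per unit of this negative logarithm.
compound 2, `COc1cc(C(=O)NS(=O)(=O)c2ccccc2Cl)ccc1Cn1ccc2ccc(NC(=O)CC3CCCC3)cc21`, gives 9.8 in this assay.

Compound 2 holds the higher of the two numbers; compound 1 sits well below it, a gap beyond the scatter. The next compound, compound 3, `COc1cc(C(=O)NS(=O)(=O)c2ccccn2)ccc1Cn1ccc2ccc(NC(=O)CC3CCCC3)cc21`, keeps the whole of compound 2 except one change: pyridin-2-yl in place of 2-chlorophenyl on a sulfonyl sulfur. Among the compounds with values here, no measured pair shows this exchange, so the size of the step is open. A modest loss is expected, the estimated step of a number 0.60 log units lower from compound 2 to compound 3 (beyond the scatter) being beyond the scatter but not large. Compound 3 is therefore estimated at 9.2, within a range from 8.4 to 9.9.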

Compound 3, negative logarithm of the antagonist equilibrium constant: 8.9
For compound 3 the middle estimate is 0.30 log units above the measured one, within the range that was stated.
By their numbers in this assay, from the lowest: compound 1; then compound 3; then compound 2.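

In this assay, within the data shown here, the sulfonyl sulfur tolerates no free exchange of its aryl group: pyridin-2-yl in place of 2-chlorophenyl gives a number 0.90 log units lower from compound 2 to compound 3 (beyond the scatter), the first step that changes one place only. The step is modest, so this position affects the read-out without the change abolishing activity. No measurement shown explains the size of this step.

A plain phenyl at this place would separate the loss of the chlorine from the gain of the ring nitrogen. On these data alone, whether the step holds with the amide chain of compound 1 also remains open.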